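Trading a methyl for a chloro on the benzyl ring

The source may report more compounds than this note shows. Statements on the series, on what has been measured and on what is new or still open speak of the compounds shown alone.

Of the compounds shown here, three sharing one core have been measured in a functional assay on CHO cells for antagonist activity at adenosine receptor A2b (Homo sapiens); a higher number here means a weaker inhibitor, a lower number a stronger inhibitor. Compound 1 `CNc1ncc(C(=O)O)c2nc(-c3ccco3)nn12` carries only hydrogen on the chain carbon bound to the ring nitrogen; in this assay compound 1 gives > 10000 nM, which is a limit of the assay and not a number. Compound 2 `CCCCC(CC)CNc1ncc(C(=O)O)c2nc(-c3ccco3)nn12` carries a 1-ethylpentyl group on that carbon; in this assay compound 2 gives > 10000 nM, again a limit. Compound 3 `Cc1ccc(CNc2ncc(C(=O)O)c3nc(-c4ccco4)nn23)cc1` carries a 4-methylphenyl there; in this assay compound 3 gives > 10000 nM, also a limit. Compound 3 therefore stands where every value shown stands, at the limit of > 10000 nM in this assay, at which 3 of the 3 values shown sit. The steps a step that the two limits leave unreadable from compound 1 to compound 2, a step that the two limits leave unreadable from compound 1 to compound 3 and a step that the two limits leave unreadable from compound 2 to compound 3 cannot be sized for that reason.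

Compound 4 `O=C(O)c1cnc(NCc2ccc(Cl)cc2)n2nc(-c3ccco3)nc12` differs from compound 3 by chloro in place of methyl on an aromatic carbon. Within the data shown here, no measured step touches this part of the molecule, and none of the measured steps can be read in size; they bear on the question only by showing that changes at the chain carbon left all three compounds at the limit. Nothing in these numbers gives a direction for the step to compound 4, so the expectation is that this assay reports a limit again, with the step of a number no higher from compound 3 to compound 4 (the limit leaves the size open) estimated as none beyond the scatter. Compound 4 is estimated at 10000 nM, within 5000 nM to 30000 nM.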

Compound 4, inhibition constant: > 30000 nM
Compound 4: a limit, no number (the forecaster's own chance of this, stated with the estimate: 85%); at least 3.0-fold (0.47 log units) between middle value and limit.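

In this assay compound 4 gives > 30000 nM, a limit of the assay and not a number. Among these compounds, compound 1, compound 2 and compound 3 also stand at limits, so no step from any of them to compound 4 can be read. The compounds shown leave open whether chloro in place of methyl changes the inhibition at all.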